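The compounds below may be only part of what the source reports. "The series", "measured", "known", "first", "only" and "open" are said of these compounds alone.

Measured so far:
Compound 1 `O=C(O)c1cncc(-c2ccc(N3CCC(Oc4cc(F)ccc4Br)CC3)nn2)c1` — in an assay on isolated protein for inhibition of acyl-CoA desaturase 1 (Rattus norvegicus) (on this read-out lower numbers stand for stronger inhibition and higher numbers for weaker inhibition), compound 1 gives 15 nM.
Compound 2 `O=C(O)c1ccc(-c2ccc(N3CCC(Oc4cc(F)ccc4Br)CC3)nn2)nc1` — in this assay compound 2 gives 8 nM.

Compound 2 has the lowest of the two numbers, but the gap to compound 1, a 1.9-fold lower number from compound 1 to compound 2 (0.27 log units; within the scatter), lies within the scatter, so the two acids cannot be ranked against each other. Compound 3 `O=C(O)Cc1cncc(-c2ccc(N3CCC(Oc4cc(F)ccc4Br)CC3)nn2)c1` differs from compound 2 in that (a group of 10 heavy atoms (7 carbon, 1 nitrogen, 2 oxygen; one six-membered aromatic ring with 1 hetero atom) in place of a group of 9 heavy atoms (6 carbon, 1 nitrogen, 2 oxygen; one six-membered aromatic ring with 1 hetero atom), on an aromatic carbon); the acid now sits on a methylene rather than directly on the ring. Among the compounds with values here, the only measured step, a 1.9-fold lower number from compound 1 to compound 2 (0.27 log units; within the scatter), concerns the position of the acid on its ring and says nothing about inserting a methylene between ring and acid, so no measured step bears directly on the change. The direction of the step cannot be read from these two compounds; a modest weakening is taken as the likeliest outcome, expected as a 3.8-fold higher number from compound 2 to compound 3 (0.57 log units; beyond the scatter). Compound 3 is therefore estimated at 30 nM, within a range from 8 nM to 120 nM.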

Compound 3, half-maximal inhibitory concentration: 20 nM
For compound 3 the middle estimate is 1.5-fold (0.18 log units) above the measured one; the measured number falls inside the stated range.
By their numbers in this assay, from the lowest: compounds 2, 1 and 3 (each within the scatter of the next, the first and the last beyond it).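

In this assay the clean test of the methylene is carboxymethyl in place of carboxy on the ring as carried in compound 1 (a 1.3-fold higher number from compound 1 to compound 3 (0.12 log units; within the scatter)), so on that ring the extra methylene gives a number that cannot be told apart from that of compound 1. Within the data shown here, the pair of compound 2 and compound 3 gives the first step beyond the scatter in this set (a 2.5-fold higher number from compound 2 to compound 3 (0.40 log units; beyond the scatter)), but the ring of compound 3 is carried as in compound 1 and not as in compound 2, so that modest step cannot be laid on the methylene alone. Nothing at hand accounts for either step.

The compounds shown leave open what carboxymethyl gives on the ring as carried in compound 2. Also open, as far as these compounds go, is whether a longer chain such as carboxyethyl, or a primary amide or tetrazole in place of the carboxylic acid, keeps the number in this range.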